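The compounds below may be only part of what the source reports. "The series", "measured", "known", "first", "only" and "open" are said of these compounds alone.

The measured compounds:
- compound 1 `COc1ccc(-c2cc(/C=C/C(=O)c3ccc(N)cc3)[nH]n2)cc1` gives 91% in a functional assay on SK-MEL-28 cells (Homo sapiens) for cytotoxicity, read by sulforhodamine B assay, with a stated time of 48 h, tested at 1 uM; a lower number here means a stronger effect, a higher number a weaker effect of the compound at the concentration tested
- compound 2 `COc1cc(-c2cc(/C=C/C(=O)c3ccc(Cl)c(Cl)c3)[nH]n2)cc(OC)c1OC` gives 114% in this assay
- compound 3 `COc1ccc(C(=O)/C=C/c2cc(-c3cc(OC)c(OC)c(OC)c3)n[nH]2)cc1` gives 101% in this assay

Compound 1 has the lowest of the three numbers in this assay; against compound 3 the gap lies within the scatter, against compound 2 beyond it. For the measured compounds named here, the one step measured in one place is a number 13 percentage points lower from compound 2 to compound 3 (beyond the scatter), a change on the carbonyl side of the shared core.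

Compound 4 `COc1ccc(-c2cc(/C=C/C(=O)c3ccc(N)cc3)[nH]n2)cc1OC` differs from compound 1 by methoxy in place of hydrogen on an aromatic carbon, on the ring that carries the methoxy group, ortho to that group. Going by the values given here, no measured step touches this part of the molecule: compound 2 and compound 3 both carry the same trimethoxyphenyl there, and the only step concerns the other aryl group. With nothing in the data bearing on this change, no step beyond the scatter is expected in this assay in either direction. Compound 4 is therefore estimated at 92%, in the range 78% to 108%, a step of a number 1 percentage points higher from compound 1 to compound 4 (within the scatter) that is expected to stay within the scatter.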

Compound 4, a percentage reported as activity, at one concentration (the size of the read-out at that concentration, not a potency): 89%
The estimate for compound 4 lay 3 percentage points above the measured number; the measured number falls inside the stated range.
By their numbers in this assay, from the lowest: compounds 4, 1 and 3 (each within the scatter of the next, the first and the last beyond it); then compound 2.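

In this assay the step is a number 2 percentage points lower from compound 1 to compound 4 (within the scatter) for methoxy in place of hydrogen on an aromatic carbon ortho to a methoxy group. For the compounds shown here, this is the first measured change on this ring, since the earlier step lay on the carbonyl side, and at this position the added methoxy does not move the read-out beyond the scatter at the single concentration tested. No measurement shown offers an explanation for this result.

The compounds shown leave open whether a hydroxy group, a fluorine atom or a longer chain such as ethoxy at this position would shift the read-out beyond the scatter. They also leave open whether the same methoxy change would remain within the scatter with a group other than the amine on the other aryl ring, such as a carboxylic acid.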